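Chain extension from compound 3 to compound 4

The source may report more compounds than this note shows. Statements on the series, on what has been measured and on what is new or still open speak of the compounds shown alone.

Measured in a functional assay on SNU-423 cells (Homo sapiens) for inhibition, read by MTT assay, with a stated time of 72 h; a lower number here means a stronger inhibitor, a higher number a weaker inhibitor
compound 1 `CNC(=O)CCCCCCCn1nc(-c2cnc3[nH]ccc3c2)c2c(N)ncnc21` gives 5400 nM
compound 2 `Nc1ncnc2c1c(-c1cnc3[nH]ccc3c1)nn2CCCCCC(=O)NO` gives "not determined" (no result reported)
compound 3 `Nc1nc2cc(-c3nn(CCCCCC(=O)NO)c4ncnc(N)c34)ccc2o1` gives 12600 nM

Of the two numbers available, the higher belongs to compound 3 (12600 nM), and the gap down to compound 1 (5400 nM) lies beyond the scatter. Unmeasured compound 4 `Nc1nc2cc(-c3nn(CCCCCCC(=O)NO)c4ncnc(N)c34)ccc2o1` carries (hydroxycarbamoyl)methyl in place of hydroxycarbamoyl on a saturated chain carbon, five bonds along the chain from an aromatic nitrogen. Among the compounds with values here, no measured pair shows this change alone, so the expectation is weakly grounded. Only a small step in this assay is expected, probably not beyond the scatter and leaning towards a lower number, with an estimated change of a 1.6-fold lower number from compound 3 to compound 4 (0.20 log units; within the scatter) (direction uncertain). Compound 4 is estimated at 8000 nM (expected range 2500 nM to 25000 nM).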

Compound 4, half-maximal inhibitory concentration: 6100 nM
Compound 4: middle estimate off by 1.3-fold (0.12 log units), on the high side; measured number inside the range.
By their numbers in this assay, from the lowest: compounds 1 and 4 (each within the scatter of the next); then compound 3.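

In this assay, within the data shown here, (hydroxycarbamoyl)methyl in place of hydroxycarbamoyl on this saturated chain carbon gives a 2.1-fold lower number from compound 3 to compound 4 (0.32 log units; beyond the scatter), the first step that isolates one change. The chain end at this position is therefore sensitive to a single added carbon, though the step is modest. Nothing available bears on the cause of this step.

As far as these compounds go, whether a longer chain would extend this step or reverse it remains open. Also open, from the compounds shown here alone, is how a carboxylic acid in place of hydroxycarbamoyl would read on this chain.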